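The source may report more compounds than this note shows. Statements on the series, on what has been measured and on what is new or still open speak of the compounds shown alone.

Working notes on the series.

Two members of the series have been measured so far. Compound 1 `Cc1cccc(Cn2c(CN3CCN(C(=O)c4ccc(C(F)(F)F)cc4)CC3)nc3ccccc32)c1` is tested in an assay on isolated protein for inhibition of aldehyde dehydrogenase 1A1 (Homo sapiens), read by spectrophotometry, tested at 10 uM (a higher number here means more inhibition at the concentration tested (going by the name of the read-out), a lower number less inhibition), and compound 1 gives 22.9%. Compound 2 `Cc1cccc(Cn2c(CN3CCN(C(=O)c4ccc(C#N)cc4)CC3)nc3ccccc32)c1` keeps the shared core and differs only at the aromatic substituent; in this assay compound 2 gives 20.8%. For the measured compounds named here, the one measured step, a number 2.1 percentage points lower from compound 1 to compound 2 (within the scatter), is within the scatter, so the two numbers cannot be ordered. Compound 2 stands on the lower of the two numbers, but no claim of a difference follows from that.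

Compound 3 `Cc1cccc(Cn2c(CN3CCN(C(=O)c4ccncc4)CC3)nc3ccccc32)c1` is the next member. Its change from compound 2 is pyridin-4-yl in place of 4-cyanophenyl on a carbonyl carbon. Going by the values given here, no measured step bears directly on this exchange: the only step available, a number 2.1 percentage points lower from compound 1 to compound 2 (within the scatter), replaces one substituent on the aromatic ring with another and leaves the ring itself in place, whereas here the whole 4-cyanophenyl is exchanged for pyridin-4-yl. The information that does exist shows a small step for a change at this position. The step expected from this exchange, a number 2.8 percentage points lower from compound 2 to compound 3 (within the scatter), is therefore taken as none beyond the scatter. Compound 3 is expected to give 18% in this assay, with a range from 4% to 32%.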

Compound 3, a percentage reported as inhibition, at one concentration (the size of the read-out at that concentration, not a potency): 20.6%
Compound 3: middle estimate off by 2.6 percentage points, on the low side; the range from low to high includes it.
By their numbers in this assay, from the lowest: compounds 3, 2 and 1 (each within the scatter of the next).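

Exchanging the whole ring on the carbonyl carbon, and not only a substituent on it, gives no readable difference in this assay: pyridin-4-yl in place of 4-cyanophenyl gives a number 0.2 percentage points lower from compound 2 to compound 3 (within the scatter), and pyridin-4-yl in place of 4-(trifluoromethyl)phenyl gives a number 2.3 percentage points lower from compound 1 to compound 3 (within the scatter). The three groups on this carbonyl carbon therefore cannot be ordered, and no difference can be assigned either to the nitrile, to the trifluoromethyl or to the ring nitrogen of pyridin-4-yl. Nothing available explains why the numbers stay together, so the result stands as an observation only.

Going by these compounds, all three groups are six-membered aromatic rings, so it remains open whether any group on this carbonyl carbon can move the number beyond the scatter, for instance a saturated cyclohexyl ring, a longer alkyl chain, or a phenyl ring carrying an amine or a carboxylic acid. On these data alone, it is also open whether the same lack of difference would hold for changes elsewhere on the shared core, since all three compounds keep the rest of it unchanged.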